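The source may hold more compounds than are shown below. What is called first, only, known or untested is meant among the compounds shown, and "the series" means these compounds.

Working notes on the series. Among the compounds with values here, compound 2 `O=C(NCCNc1nccc(-c2c(-c3cccc(F)c3)nc3sccn23)n1)c1ccccc1` is the only compound with a number in a functional assay on SK-MEL-28 cells (Homo sapiens) for cytotoxicity, read by MTT assay; on this read-out lower numbers stand for stronger inhibition and higher numbers for weaker inhibition; in this assay compound 2 gives 17000 nM. Compound 1 `O=C(NCCCNc1nccc(-c2c(-c3cccc(F)c3)nc3sccn23)n1)c1ccc(Cl)cc1` returns only a limit, > 20000 nM, rather than a number. Within the data shown here, the one measured step, an at least 1.1-fold lower number from compound 1 to compound 2 (0.07 log units; that floor lies within the scatter), touches both the chain length and the chlorine on the aryl, and its floor rests on the limit described by the limit of > 20000 nM in this assay, at which 1 of the 2 values shown sits; it says little about the aryl alone.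

Compound 3 `O=C(NCCNc1nccc(-c2c(-c3cccc(F)c3)nc3sccn23)n1)c1c(F)cccc1F` differs from compound 2 as 2,6-difluorophenyl in place of phenyl on a carbonyl carbon. Among the measured compounds shown here, no measured step changes the ring on the carbonyl carbon by fluorine, so nothing here sets the direction for this change. Given that compound 2 sits weakly at 17000 nM, the expectation is a step of a 1.1-fold lower number from compound 2 to compound 3 (0.05 log units; within the scatter), not beyond the scatter. Compound 3 is therefore estimated at 15000 nM, within a range from 6000 nM to 40000 nM, with a real chance that only a limit is returned.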

Compound 3, half-maximal inhibitory concentration: 11400 nM
Compound 3: middle estimate off by 1.3-fold (0.12 log units), on the high side; measured number inside the range.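

Within the data shown here, the only measured step that changes the ring on the carbonyl carbon alone, 2,6-difluorophenyl in place of phenyl, is a 1.5-fold lower number from compound 2 to compound 3 (0.17 log units; within the scatter) in this assay. At this position, then, the two fluorines do not separate compound 3 from compound 2 on this read-out, and both compounds remain in the same part of the scale, with no direction established for the change. The wider comparison, which alters the chain and the aryl together, is an at least 1.7-fold lower number from compound 1 to compound 3 (0.24 log units; that floor lies within the scatter); its floor is set by the limit returned for compound 1 and not by a number, so it cannot assign a contribution to either change: the limit of > 20000 nM in this assay, at which 1 of the 3 values shown sits.

Still open, from the compounds shown here alone, is whether any group on this ring can move the read-out beyond the scatter, for instance an amine or a carboxylic acid in place of the fluorines. Also open, going by these compounds, is what the chain contributes on its own, which would take a longer chain carrying the same benzamido group or the same 2,6-difluorophenyl carbonyl group, with the aryl held constant.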